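A few compounds are considered here, and "the series" means these few. Any claim that something is new, unique, unknown or untested is made for them only; others in the source may bear on it.

In an ADME assay on J774 cells (Mus musculus) for cytotoxicity, read by MTT assay, with a stated time of 48 h (a lower number here means a stronger inhibitor, a higher number a weaker inhibitor), compound 1 `NCCNc1cc(/C=C/c2ccccc2)nc2ccccc12` gives 4600 nM and compound 2 `NCCCCNc1cc(/C=C/c2ccccc2)nc2ccccc12` gives 6600 nM, while compound 3 `CN(C)CC(=O)NCCNc1cc(/C=C/c2ccccc2)nc2ccccc12` has the highest number of the three at 15000 nM. Compound 4 `CC(=O)Nc1cc(/C=C/c2ccccc2)nc2ccccc12` carries acetyl in place of 2-((((dimethylamino)methyl)carbonyl)amino)ethyl on a nitrogen on an aromatic ring. Among the compounds with values here, no measured step makes this exact change. The nearest guides are a 3.3-fold higher number from compound 1 to compound 3 (0.51 log units; beyond the scatter) and a 2.3-fold higher number from compound 2 to compound 3 (0.36 log units; beyond the scatter), both modest, and a 1.4-fold higher number from compound 1 to compound 2 (0.16 log units; within the scatter), which stays within the scatter. A small upward move or none beyond the scatter is therefore expected in this assay. The expected step is a 1.3-fold higher number from compound 3 to compound 4 (0.12 log units; within the scatter). For compound 4 the estimated value is 20000 nM, with an expected range of 7000 nM to 60000 nM.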

Compound 4, half-maximal inhibitory concentration: > 25000 nM
Compound 4: only a limit was reported; the forecaster's own chance of this, stated with the estimate: 25%; middle value at least 1.2-fold (0.09 log units) away from the limit.
By their numbers in this assay, from the lowest: compounds 1 and 2 (each within the scatter of the next); then compound 3. At a limit, above all of these: compound 4.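

In this assay compound 4 gives only a limit, not a number: the limit of > 25000 nM in this assay, at which 1 of the 4 values shown sits. On this nitrogen on an aromatic ring, acetyl gives an at least 5.4-fold higher number from compound 1 to compound 4 (0.73 log units; beyond the scatter) and an at least 3.7-fold higher number from compound 2 to compound 4 (0.57 log units; beyond the scatter), so this short group, which carries no amine, moves the number further than any earlier step did. Against the longer amide chain the result is weaker, with an at least 1.6-fold higher number from compound 3 to compound 4 (0.22 log units; that floor lies within the scatter), so the size of that step stays unsettled.

On these data alone, it remains open whether the acetyl carbonyl or the missing amine matters here. A hydrogen or a simple ethyl group on this nitrogen could separate the two.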